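Removing the methoxy group from compound 3

A few compounds are considered here, and "the series" means these few. Any claim that something is new, unique, unknown or untested is made for them only; others in the source may bear on it.

In an ADME assay on MCF-10A cells (Homo sapiens) for cytotoxicity, read by sulforhodamine B assay, with a stated time of 72 h, tested at 10 uM (on this read-out lower numbers stand for a weaker effect and higher numbers for a stronger effect at the one concentration tested), compound 3 `COc1cc(Br)cc(/C=C/C(=O)c2ccc(C)cc2)c1O` gives 155%, the highest of the three measured numbers. Compound 1 `COc1cc(Br)cc(/C=C/C(=O)c2ccccc2)c1O` gives 34.4% and compound 2 `Cc1ccc(C(=O)/C=C/c2cc(Cl)ccc2O)cc1` gives 33.5% in this assay. Among the compounds with values here, the only measured step, a number 120.6 percentage points higher from compound 1 to compound 3 (beyond the scatter), concerns a different part of the molecule. Compound 4 `Cc1ccc(C(=O)/C=C/c2cc(Br)ccc2O)cc1` differs from compound 3 by hydrogen in place of methoxy on an aromatic carbon. Within the data shown here, no measured step bears directly on this change, but compound 2, which also lacks the methoxy group and carries the methyl group, gives a low number in this assay. Compound 4 is therefore expected to sit well below compound 3, with the step of a number 95 percentage points lower from compound 3 to compound 4 (beyond the scatter) meant as a large drop, though the uncertainty is wide. The estimate for compound 4 is 60%, within 25% to 130%.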

Compound 4, a percentage reported as activity, at one concentration (the size of the read-out at that concentration, not a potency): 32.4%
Compound 4: the middle estimate sits 27.6 percentage points above what was measured, within the range that was stated.
By their numbers in this assay, from the lowest: compounds 4, 2 and 1 (each within the scatter of the next); then compound 3.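

Hydrogen in place of methoxy on this aromatic carbon, ortho to a hydroxy group, gives a number 122.6 percentage points lower from compound 3 to compound 4 (beyond the scatter) in this assay and so the high number of compound 3 is lost without the methoxy group, just as it is without the methyl group. Bromo in place of chloro gives a number 1.1 percentage points lower from compound 2 to compound 4 (within the scatter) and does not separate these two compounds. Nothing measured here explains why the methoxy group counts for so much.

As far as these compounds go, whether an ethoxy group or an amine on this carbon would keep the high number remains open. So does whether chloro in place of bromo would keep it with both the methoxy and methyl groups present.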